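The source may hold more compounds than are shown below. What is called first, only, known or untested is meant among the compounds shown, and "the series" means these compounds.

Compound 1 `Cc1cccc(CNC(=O)c2nn(-c3ccc(F)cc3)c(OC[C@@H](O)C[C@@H](O)CC(=O)O)c2C(C)C)c1`: 4.9 nM
Compound 2 `Cc1ccccc1CNC(=O)c1nn(-c2ccc(F)cc2)c(OC[C@@H](O)C[C@@H](O)CC(=O)O)c1C(C)C`: 17 nM

In an assay on microsomes from liver for inhibition of 3-hydroxy-3-methylglutaryl-coenzyme A reductase (Rattus norvegicus) (a higher number here means a weaker inhibitor, a lower number a stronger inhibitor), compound 2 stands at the higher of the two numbers; its nearest neighbour is compound 1, and the step of a 3.5-fold higher number from compound 1 to compound 2 (0.54 log units; beyond the scatter) is modest but beyond the scatter. Compound 3 `CC(C)c1c(C(=O)N(C)Cc2cccc(F)c2)nn(-c2ccc(F)cc2)c1OC[C@@H](O)C[C@@H](O)CC(=O)O` carries (3-fluorobenzyl)(methyl)amino in place of (2-methylbenzyl)amino on a carbonyl carbon. Among the measured compounds shown here, only that one measured step bears on the change: 2-methylphenyl in place of 3-methylphenyl raised the number, so returning to a group on the 3-position of the ring may reverse part of it, while the methyl on the nitrogen and the fluorine have no measured counterpart. A modest fall is therefore expected, a 1.7-fold lower number from compound 2 to compound 3 (0.23 log units; within the scatter), and the estimate for compound 3 is 10 nM, within 3 nM to 35 nM.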

Compound 3, half-maximal inhibitory concentration: 14 nM
Estimate against measurement, compound 3: 1.4-fold (0.15 log units) below, and the stated range covers the measured number.
By their numbers in this assay, from the lowest: compound 1; then compounds 3 and 2 (each within the scatter of the next).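

With (3-fluorobenzyl)(methyl)amino on the carbonyl carbon, a group with no hydrogen-bond donor can stand at this position without leaving the scatter of the (2-methylbenzyl)amino analogue: the change gives a 1.2-fold lower number from compound 2 to compound 3 (0.08 log units; within the scatter). Against the (3-methylbenzyl)amino analogue, the same group gives a 2.9-fold higher number from compound 1 to compound 3 (0.46 log units; beyond the scatter), so a substituent on the 3-position of the ring does not by itself restore the lower number. Nothing measured here explains either step. As far as these compounds go, the methyl on the nitrogen and the fluorine enter together, so their separate contributions remain open. A (3-fluorobenzyl)amino or (3-methylbenzyl)(methyl)amino group on the same carbonyl carbon would separate them.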